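The compounds below may be only part of what the source reports. "The series", "measured", "known", "first", "only" and "open" are said of these compounds alone.

Of the compounds shown here, three of a shared core have been measured in a functional assay on NCI-H460 cells (Homo sapiens) for antiproliferative activity, read by MTT assay, with a stated time of 48 h; a higher number here means a weaker inhibitor, a lower number a stronger inhibitor. Compound 1 `COc1cccc(-c2nc3cccc(-c4cc(OC)c(OC)c(OC)c4)c3o2)c1` carries a 3-methoxyphenyl on the core, and for compound 1 this assay reports only a limit, > 25000 nM, which is the ceiling of the measurement (the limit of > 25000 nM in this assay, at which 1 of the 3 values shown sits). Compound 2 `COc1cc(-c2cccc3nc(-c4ccc(F)cc4)oc23)cc(OC)c1OC` bears a 4-fluorophenyl in its place and gives 8700 nM, the step being an at least 2.8-fold lower number from compound 1 to compound 2 (0.45 log units; beyond the scatter). Compound 3 `COc1cc(-c2cccc3nc(-c4cccc(Br)c4)oc23)cc(OC)c1OC` bears a 3-bromophenyl and gives 3800 nM, the lowest of the two numbers; it is separated from compound 2 by a 2.3-fold lower number from compound 2 to compound 3 (0.36 log units; beyond the scatter) and from compound 1 by an at least 6.5-fold lower number from compound 1 to compound 3 (0.81 log units; beyond the scatter).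

Compound 4 `COc1cc(-c2cccc3nc(-c4ccc5cc[nH]c5c4)oc23)cc(OC)c1OC` alters the same group: 1H-indol-6-yl in place of 3-bromophenyl on an aromatic carbon. All three measured steps change the aryl group on this same carbon of the core, and each of them lowered the number, running from the methoxy-bearing ring through the fluorine-bearing ring to the bromine-bearing ring. The 1H-indol-6-yl, however, is of a different kind from the substituted phenyl rings measured so far, so the direction of those steps cannot simply be carried over, and the expectation is broad. The author expects a step of a 1.1-fold higher number from compound 3 to compound 4 (0.02 log units; within the scatter), within the scatter, and estimates for compound 4 a value of 4000 nM, lying between 1200 nM and 15000 nM.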

Compound 4, half-maximal inhibitory concentration: 24 nM
The estimate for compound 4 lay 170-fold (2.22 log units) above the measured number; measured number outside the range, below it.
By their numbers in this assay, from the lowest: compound 4; then compound 3; then compound 2. At a limit, above all of these: compound 1.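

In this assay, the steps among the substituted phenyl rings at this position, on an aromatic carbon next to the ring nitrogen and next to the ring oxygen, stayed small, such as a 2.3-fold lower number from compound 2 to compound 3 (0.36 log units; beyond the scatter), whereas the 1H-indol-6-yl gives a 160-fold lower number from compound 3 to compound 4 (2.20 log units; beyond the scatter), showing that this position can respond far more strongly than those rings indicated. The gain holds against the other aryl groups too, with a 360-fold lower number from compound 2 to compound 4 (2.56 log units; beyond the scatter) and an at least 1000-fold lower number from compound 1 to compound 4 (3.01 log units; beyond the scatter); the entering group brings both a five-membered aromatic ring and a hydrogen-bond donor, and these compounds cannot separate the two. Compound 1 is held at a limit and not at a number, so its step gives only a minimum size: the limit of > 25000 nM in this assay, at which 1 of the 4 values shown sits.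

The compounds shown leave open whether the gain depends on the hydrogen on the indole nitrogen, which a methyl group on that nitrogen, or a benzofuran-6-yl with oxygen in its place, would address. They also leave open whether the attachment point matters, as a 1H-indol-5-yl group would show, and whether the gain persists when the methoxy groups on the other aryl ring give way to an amine.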